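Series notes: nitro in place of chloro

A few compounds are considered here, and "the series" means these few. Any claim that something is new, unique, unknown or untested is made for them only; others in the source may bear on it.

Compound 2 `CC1=CC[C@H](C(C)(C)NC(=S)N/N=C/c2cccc(Cl)c2)CC1` stands lowest of the two numbers, giving 9000 nM in a functional assay on UACC-62 cells (Homo sapiens) for inhibition, read by sulforhodamine B assay, with a stated time of 48 h; on this read-out higher numbers stand for weaker inhibition of growth and lower numbers for stronger inhibition of growth. Compound 1 `CC1=CC[C@H](C(C)(C)NC(=S)N/N=C/c2ccccc2)CC1` gives 31600 nM there, and chloro in place of hydrogen on an aromatic carbon brought a 3.5-fold lower number from compound 1 to compound 2 (0.55 log units; beyond the scatter). Compound 3 `CC1=CC[C@H](C(C)(C)NC(=S)N/N=C/c2cccc([N+](=O)[O-])c2)CC1` differs from compound 2 by nitro in place of chloro on an aromatic carbon. For the measured compounds named here, no measured step exchanges one group for another at this carbon; the only step that bears on it, a 3.5-fold lower number from compound 1 to compound 2 (0.55 log units; beyond the scatter), shows that a group at this carbon moved the number modestly. The step of a 1.1-fold lower number from compound 2 to compound 3 (0.05 log units; within the scatter) is therefore expected to stay within the scatter. Compound 3 is estimated at 8000 nM, range 3000 nM to 25000 nM.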

Compound 3, concentration for 50% growth inhibition: > 100000 nM
Compound 3: a limit, no number; the forecaster's own chance of this, stated with the estimate: 5%; middle value at least 12-fold (1.09 log units) from the limit.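

In this assay compound 3 gives a limit and not a number: the limit of > 100000 nM in this assay, at which 1 of the 3 values shown sits. For the compounds shown here, the earlier compounds showed only that a group at this carbon could lower the number; here the identity of the group decides the direction, with nitro in place of chloro giving an at least 11-fold higher number from compound 2 to compound 3 (1.04 log units; beyond the scatter) in the same read-out. Against the unsubstituted core, nitro in place of hydrogen gives an at least 3.1-fold higher number from compound 1 to compound 3 (0.50 log units; beyond the scatter), opposite in direction to chloro in compound 2.

From the compounds shown here alone, whether an amine or a methoxy group at this carbon would follow chloro or nitro stays open. Three compounds give no cause for the reversal.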